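Biaryl series: methoxy to hydrogen at the outer ring

The source may hold more compounds than are shown below. What is called first, only, known or untested is meant among the compounds shown, and "the series" means these compounds.

Compound 1 `COc1ccccc1-c1ccc2ncn(-c3cc(OC)c(OC)c(OC)c3)c2c1` gives 5050 nM in a functional assay on SGC-7901 cells (Homo sapiens) for antiproliferative activity, read by MTT assay, with a stated time of 72 h; on this read-out higher numbers stand for weaker inhibition and lower numbers for stronger inhibition.
Compound 2 `COc1cc(-n2cnc3ccc(-c4ccccc4Cl)cc32)cc(OC)c1OC` gives in this assay only a limit, > 10000 nM.
Compound 3 `COc1cc(-n2cnc3ccc(-c4ccc(C(C)=O)cc4)cc32)cc(OC)c1OC` gives 450 nM in this assay.

Among the two numbers known, compound 1 stands highest; the nearest is compound 3, reached by an 11-fold lower number from compound 1 to compound 3 (1.05 log units; beyond the scatter). Compound 2 is reported only as a limit (the limit of > 10000 nM in this assay, at which 1 of the 3 values shown sits), so no number is known for it.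

Compound 4 `COc1cc(-n2cnc3ccc(-c4ccccc4)cc32)cc(OC)c1OC` differs from compound 1 by hydrogen in place of methoxy on an aromatic carbon. Within the data shown here, no measured step removes a group outright; the steps that bear on this one all exchange the 2-methoxyphenyl: an at least 1.9-fold higher number from compound 1 to compound 2 (0.29 log units; that floor lies within the scatter), an 11-fold lower number from compound 1 to compound 3 (1.05 log units; beyond the scatter), and between the other two compounds an at least 22-fold lower number from compound 2 to compound 3 (1.34 log units; beyond the scatter). The gain in compound 3 comes with a 4-acetylphenyl, a change not shared by compound 4. Both compounds carrying a group where compound 4 carries hydrogen sit at the weak end, so for compound 4 a step within the scatter is expected, a 1.3-fold lower number from compound 1 to compound 4 (0.10 log units; within the scatter). Compound 4 is estimated at 4000 nM, with a range from 1500 nM to 12000 nM.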

Compound 4, half-maximal inhibitory concentration: 290 nM
Compound 4: middle estimate off by 14-fold (1.14 log units), on the high side; measured number below the stated range.
By their numbers in this assay, from the lowest: compounds 4 and 3 (each within the scatter of the next); then compound 1. At a limit, above all of these: compound 2.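

Plain phenyl at this outer ring sits at the potent end of this assay: a 17-fold lower number from compound 1 to compound 4 (1.24 log units; beyond the scatter), so the methoxy ortho to a large group marks the difference between weak and potent here, and no added group is needed to reach the low numbers. The acetyl no longer stands out, given a 1.6-fold lower number from compound 3 to compound 4 (0.19 log units; within the scatter), and the earlier step to compound 3 can be read as much as the absence of the 2-methoxy as the presence of the 4-acetyl. The chloro case gives an at least 34-fold lower number from compound 2 to compound 4 (1.53 log units; beyond the scatter), which is a floor and not a size, as compound 2 stands only at a limit: the limit of > 10000 nM in this assay, at which 1 of the 4 values shown sits.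

Open, from the compounds shown here alone, is whether fluoro or hydroxyl in this same place behaves like hydrogen or like methoxy. Also open, going by these compounds, is whether an amine or a carboxylic acid on the outer phenyl holds the level of compound 4.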